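The compounds below may be only part of what the source reports. "The series", "measured", "known", "first", "only" and "open" are said of these compounds alone.

Four compounds share one core and differ at two points: the group on an aromatic nitrogen of that core and a saturated ring carbon at the far end of the side chain. Compound 1 `COc1cc2c(Oc3ccc(NC(=O)c4nn(-c5ccccc5C(F)(F)F)c(=O)cc4C)cc3F)ccnc2cc1OCCCN1CCCCC1` carries a 2-(trifluoromethyl)phenyl at the first point and an unsubstituted ring carbon at the second; in a functional assay on NCI-H460 cells (Homo sapiens) for inhibition, read by MTT assay, with a stated time of 72 h (on this read-out lower numbers stand for stronger inhibition and higher numbers for weaker inhibition), compound 1 gives 210 nM. Compound 2 `COc1cc2c(Oc3ccc(NC(=O)c4nn(-c5ccccc5C(F)(F)F)c(=O)cc4C)cc3F)ccnc2cc1OCCCN1CCC(C)CC1` differs from compound 1 by methyl in place of hydrogen on a saturated ring carbon, and in this assay compound 2 gives 200 nM, which is a 1.1-fold lower number from compound 1 to compound 2 (0.02 log units; within the scatter). Among the compounds with values here, compound 3 `COc1cc2c(Oc3ccc(NC(=O)c4nn(-c5ccc(Cl)cc5)c(=O)cc4C)cc3F)ccnc2cc1OCCCN1CCCCC1` differs from compound 1 by 4-chlorophenyl in place of 2-(trifluoromethyl)phenyl on an aromatic nitrogen; in this assay compound 3 gives 460 nM, a 2.2-fold higher number from compound 1 to compound 3 (0.34 log units; beyond the scatter), and it stands as the highest number of the three measured so far.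

Compound 4 `COc1cc2c(Oc3ccc(NC(=O)c4nn(-c5ccc(Cl)cc5)c(=O)cc4C)cc3F)ccnc2cc1OCCCN1CCC(C)CC1` is not yet measured. It differs from compound 3 by methyl in place of hydrogen on a saturated ring carbon, and since its place line reads word for word as for the step from compound 1 to compound 2, this is the same change, made this time on the core of compound 3 rather than that of compound 1.

Within the data shown here, the one earlier instance of this change, from compound 1 to compound 2, stayed within the scatter. On that single example, compound 4 is expected to land at about a 1.1-fold lower number from compound 3 to compound 4 (0.03 log units; within the scatter) from compound 3, because compound 3 gives 460 nM and the earlier methyl step moved little. Among the measured compounds shown here, the estimate for compound 4 in this assay is 430 nM, with a likely range from 220 nM to 850 nM; with only one precedent on a different core, the range is kept wide.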

Compound 4, half-maximal inhibitory concentration: 370 nM
Compound 4: the middle estimate sits 1.2-fold (0.07 log units) above what was measured, and the stated range covers the measured number.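

In this assay, piperidin-1-yl gives way to 4-methylpiperidin-1-yl with 4-chlorophenyl on the aromatic nitrogen, giving a 1.2-fold lower number from compound 3 to compound 4 (0.09 log units; within the scatter), and the methyl change carries across the two cores without a difference that can be told from scatter: the same change on two cores in this assay, a 1.1-fold lower number (0.02 log units; within the scatter) from compound 1 to compound 2 and a 1.2-fold lower number (0.09 log units; within the scatter) from compound 3 to compound 4, 1.2-fold (0.07 log units) apart, within the scatter of two such steps. The second change can be read from the same four compounds, since 4-chlorophenyl in place of 2-(trifluoromethyl)phenyl with the 4-methylpiperidin-1-yl end gives a 1.9-fold higher number from compound 2 to compound 4 (0.27 log units; within the scatter); although only the earlier of its two steps lies beyond the scatter, the two steps themselves agree: the same change on two cores in this assay, a 2.2-fold higher number (0.34 log units; beyond the scatter) from compound 1 to compound 3 and a 1.9-fold higher number (0.27 log units; within the scatter) from compound 2 to compound 4, 1.2-fold (0.07 log units) apart, within the scatter of two such steps. This shows that, within these four compounds and this one assay, the two changes behave independently as far as can be measured, but it rests on just two pairs for each change and does not show that the same holds for other groups at either point or gives any reason for the agreement.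

The compounds shown leave open how the read-out would respond to an ethyl or a hydroxyl group on the saturated ring carbon in place of the methyl, or to an unsubstituted phenyl on the aromatic nitrogen. They also leave open whether a longer chain leading to the piperidine would keep the two changes as independent as they appear here.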